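From an Oxetane Carbamate to a Thiocarbamate

A few compounds are considered here, and "the series" means these few. Any claim that something is new, unique, unknown or untested is made for them only; others in the source may bear on it.

Compound 1 `Cc1nc(S(C)(=O)=O)ccc1Oc1ncnc(OC2CCN(C(=O)OC3CCC3)CC2)c1F`: 167 nM
Compound 2 `Cc1nc(S(C)(=O)=O)ccc1Oc1ncnc(OC2CCN(C(=O)O[C@H](C)C(F)(F)F)CC2)c1F`: 110 nM
Compound 3 `Cc1nc(S(C)(=O)=O)ccc1Oc1ncnc(OC2CCN(C(=O)OC3(C(F)(F)F)COC3)CC2)c1F`: 342 nM

Three compounds share a core and differ only in the group on the oxygen of a carbamate; all were tested in a functional assay on isolated protein for inhibition of Glucose-dependent insulinotropic receptor (Rattus norvegicus), read by HTRF and cAMP accumulation; on this read-out lower numbers stand for an effect already at smaller amounts and higher numbers for an effect only at larger amounts of compound. Compound 3 gives the highest number of the three: a 2.0-fold higher number from compound 1 to compound 3 (0.31 log units; beyond the scatter), and a 3.1-fold higher number from compound 2 to compound 3 (0.49 log units; beyond the scatter). The smaller change between compound 1 and compound 2 stays within the scatter: a 1.5-fold lower number from compound 1 to compound 2 (0.18 log units; within the scatter).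

Compound 4 `Cc1nc(S(C)(=O)=O)ccc1Oc1ncnc(OC2CCN(C(=O)SC(C)(C)C)CC2)c1F` is not yet measured. It differs from compound 3 in one place: (tert-butyl)sulfanyl in place of (3-(trifluoromethyl)oxetan-3-yl)oxy on a carbonyl carbon. Within the data shown here, no measured pair swaps oxygen for sulfur here, so the steps bear only loosely on this change. What they do show is that the oxetane-bearing group of compound 3 sits at the high end, while the two plain alkyl groups of compound 1 and compound 2 sit lower. Since the tert-butyl group of compound 4 is again a small alkyl group without a ring, the number is expected to move back toward those of compound 1 and compound 2, i.e. a modest decrease, as in a 2.1-fold lower number from compound 3 to compound 4 (0.33 log units; beyond the scatter). Compound 4 is therefore estimated at 160 nM, with a range from 60 nM to 450 nM to cover the unmeasured sulfur swap.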

Compound 4, half-maximal effective concentration: 30.7 nM
Compound 4: the middle estimate sits 5.2-fold (0.72 log units) above what was measured, outside the stated range (below it).
By their numbers in this assay, from the lowest: compound 4; then compounds 2 and 1 (each within the scatter of the next); then compound 3.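

In this assay, replacing the oxygen-linked group on the carbonyl carbon with (tert-butyl)sulfanyl lowers the number beyond the scatter in all three comparisons: an 11-fold lower number from compound 3 to compound 4 (1.05 log units; beyond the scatter), a 3.6-fold lower number from compound 2 to compound 4 (0.55 log units; beyond the scatter) and a 5.4-fold lower number from compound 1 to compound 4 (0.74 log units; beyond the scatter). Among these compounds, this position can therefore carry a much larger change than the earlier compounds revealed, since their widest step was a 3.1-fold higher number from compound 2 to compound 3 (0.49 log units; beyond the scatter), and compound 4 now has the lowest number of the four. Each of these steps changes the linking atom from oxygen to sulfur and the group attached to it at the same time, so they cannot show which of the two changes matters, and no measurement at hand explains the drop.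

A tert-butoxy group on the same carbonyl carbon would separate the two changes, showing whether the tert-butyl group alone brings the number close to that of compound 4. As far as these compounds go, it also remains open whether a cyclobutylsulfanyl group or a tert-butylamino group in this place would give a similarly low number.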